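Bromo Substitution on Two Related Cores

This account rests on a few compounds, and the source may have more. Where it says the series, first, only, none or still open, it means among the compounds named here.

Compound 1 `O=C(NS(=O)(=O)c1cccc([N+](=O)[O-])c1)n1ccc2cccnc21`: 70.7% in a functional assay on MCF7 cells (Homo sapiens) for antiproliferative activity, read by MTT assay, with a stated time of 24 h, tested at 10 uM; a lower number here means less inhibition, a higher number more inhibition at the concentration tested (going by the name of the read-out)
Compound 2 `O=C(NS(=O)(=O)c1ccc2ccccc2c1)n1ccc2cccnc21`: 1.9% in this assay
Compound 3 `O=C(NS(=O)(=O)c1cccc([N+](=O)[O-])c1)n1ccc2cc(Br)cnc21`: 43.1% in this assay

Of the compounds shown here, three have been measured. Compound 1 and compound 3 share a core and differ in one place: bromo in place of hydrogen on an aromatic carbon. This single change gives the step of a number 27.6 percentage points lower from compound 1 to compound 3 (beyond the scatter) in this assay, so the bromo compound inhibits less than its hydrogen parent.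

Compound 2 carries a different group on the other side of the molecule; the difference between the two cores is not broken down here. Compound 2 gives the lowest number of the three, and both compound 1 and compound 3 stand beyond the usual scatter above it, so its inhibition in this assay is the lowest of the measured set.

Compound 4 `O=C(NS(=O)(=O)c1ccc2ccccc2c1)n1ccc2cc(Br)cnc21` has not yet been measured. It differs from compound 2 by bromo in place of hydrogen on an aromatic carbon. The place is described in the same words as for the change from compound 1 to compound 3, so this is the same change on the second core.

The step from compound 2 to compound 4 is expected to be a number 2.1 percentage points higher from compound 2 to compound 4 (within the scatter), much smaller than a number 27.6 percentage points lower from compound 1 to compound 3 (beyond the scatter), because compound 2 already gives 1.9% and a percentage of inhibition cannot fall far below that. Compound 4 is estimated at 4%, with a range from 0% to 18%.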

Compound 4, a percentage reported as inhibition, at one concentration (the size of the read-out at that concentration, not a potency): 28.8%
Estimate against measurement, compound 4: 24.8 percentage points below; the measured number lies above the stated range.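

In this assay, bromo in place of hydrogen on an aromatic carbon gives a number 26.9 percentage points higher from compound 2 to compound 4 (beyond the scatter), so on this core the bromo compound inhibits more than its hydrogen parent. The same change therefore does not carry over from one core to the other with the same outcome, since the two steps run in opposite directions and the gap between them is beyond the scatter: the same change on two cores in this assay, a number 27.6 percentage points lower (beyond the scatter) from compound 1 to compound 3 and a number 26.9 percentage points higher (beyond the scatter) from compound 2 to compound 4, 54.5 percentage points apart, beyond the scatter of two such steps. This shows that, in these two pairs, the outcome of adding bromo depends on the rest of the molecule, but it does not show why, and two pairs give no rule for other cores; each number is also a reading at one concentration, not a potency.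

The compounds shown leave open whether another group on the same aromatic carbon, such as chloro, methyl or an amine, would lower the inhibition as in compound 3 or raise it as in compound 4. They also leave open how the bromo change would behave with a third group on the other side of the molecule, such as a phenyl ring carrying a carboxylic acid.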